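A group swap from compound 1 to compound 3

The compounds below may be only part of what the source reports. "The series", "measured", "known", "first", "only" and "open" are said of these compounds alone.

In a physicochemical assay for solubility, in simulated intestinal fluid, at pH 6.8 (on this read-out lower numbers stand for lower solubility and higher numbers for higher solubility), compound 1 (`C[C@H](C(=O)N(Cc1ccc(C2CCCCC2)cc1)c1ccc(C(=O)O)c(O)c1)N(C)S(=O)(=O)c1c(F)c(F)c(F)c(F)c1F`) gives 127 ug/mL, the higher of the two numbers available and beyond the scatter from compound 2 (`CN(CC(=O)N(Cc1ccc(C2CCCCC2)cc1)c1ccc(C(=O)O)cc1)S(=O)(=O)c1c(F)c(F)c(F)c(F)c1F`), which gives 14 ug/mL. Compound 3 (`C[C@H](C(=O)N(Cc1ccc(C2CCCCC2)cc1)c1ccc(C(=O)NO)cc1F)N(C)S(=O)(=O)c1c(F)c(F)c(F)c(F)c1F`) remains unmeasured. On an amide-type nitrogen it carries 2-fluoro-4-(hydroxycarbamoyl)phenyl in place of 4-carboxy-3-hydroxyphenyl on an amide-type nitrogen. Among the compounds with values here, no measured pair shows this change alone, so the size of the step is uncertain. A fall beyond the scatter in this assay is expected, with compound 2 at 14 ug/mL as a guide to how low these numbers can lie. The expected step is a 5.1-fold lower number from compound 1 to compound 3 (0.71 log units; beyond the scatter). Compound 3 is estimated at 25 ug/mL, with an expected range from 6 ug/mL to 100 ug/mL.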

Compound 3, solubility: 72 ug/mL
The estimate for compound 3 lay 2.9-fold (0.46 log units) below the measured number; low and high end bracket the measured number.
By their numbers in this assay, from the lowest: compound 2; then compounds 3 and 1 (each within the scatter of the next).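

In this assay, the first step read at this position, placing 2-fluoro-4-(hydroxycarbamoyl)phenyl in place of 4-carboxy-3-hydroxyphenyl on the amide-type nitrogen gives a 1.8-fold lower number from compound 1 to compound 3 (0.25 log units; within the scatter) and so stays within the scatter. Within the data shown here, the position therefore accepts this exchange of the whole ring substituent with no measurable step, although compound 3 has no carboxy group. From the compounds shown here alone, because both the fluorine and the hydroxycarbamoyl group enter together, their separate contributions remain unresolved, and whether an amine or a primary carboxamide in place of the hydroxycarbamoyl group would behave alike remains open. Nothing at hand accounts for the size of this step.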